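A fluoro added to compound 1

A few compounds are considered here, and "the series" means these few. Any claim that something is new, unique, unknown or untested is made for them only; others in the source may bear on it.

compound 1 `CN(C)C(=O)c1cc2cnc(Nc3ccc(NC(=O)C4(C(=O)Nc5ccc(F)cc5)CC4)cc3)nc2n1C1CCCC1` at 93.3%
compound 2 `CN(C)C(=O)c1cc2cnc(Nc3ccc(NC(=O)C4(C(=O)Nc5cccc(O)c5)CC4)cc3)nc2n1C1CCCC1` at 77.5%
compound 3 `CN(C)C(=O)c1cc2cnc(Nc3ccc(NC(=O)C4(C(=O)Nc5ccccc5F)CC4)cc3)nc2n1C1CCCC1` at 70.2%

All three compounds were read in a functional assay on NCI-H1299 cells (Homo sapiens) for inhibition, read by CCK-8 assay, with a stated time of 72 h, tested at 1 uM (on this read-out higher numbers stand for more inhibition of growth at the one concentration tested and lower numbers for less inhibition of growth), and compound 1 stands highest of them with 93.3% as its value. The two steps away from it, a number 15.8 percentage points lower from compound 1 to compound 2 (beyond the scatter) and a number 23.1 percentage points lower from compound 1 to compound 3 (beyond the scatter) both exchange the 4-fluorophenyl on an amide-type nitrogen for another aryl group. The remaining step, a number 7.3 percentage points lower from compound 2 to compound 3 (within the scatter) concerns that same group.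

Compound 4 `CN(C)C(=O)c1cc2cnc(Nc3ccc(NC(=O)C4(C(=O)Nc5ccc(F)cc5)CC4)cc3F)nc2n1C1CCCC1` keeps the 4-fluorophenyl and instead carries fluoro in place of hydrogen on an aromatic carbon, ortho to a large group and meta to a large group, a difference counted as fluoro in place of hydrogen on an aromatic carbon in full. Among the measured compounds shown here, no measured step touches that ring, so the evidence is only indirect. The steps from compound 1 show that a single change elsewhere in the molecule can lower the read-out modestly, and compound 1 leaves little room above it. A small fall is therefore expected, with no step beyond the scatter as the likeliest outcome. The estimated step is a number 8.3 percentage points lower from compound 1 to compound 4 (within the scatter) and its size remains uncertain. In this assay compound 4 is expected at 85% with an estimated range from 66% to 97% for a single measurement.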

Compound 4, percent growth inhibition at one concentration: 52.3%
Beside the measured number, compound 4's estimate is 32.7 percentage points above it; measured number below the stated range.
By their numbers in this assay, from the lowest: compound 4; then compounds 3 and 2 (each within the scatter of the next); then compound 1.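

In this assay, a single fluoro in place of hydrogen on an aromatic carbon, ortho to a large group and meta to a large group, gives a number 41 percentage points lower from compound 1 to compound 4 (beyond the scatter), the only step shown that is classed as large. Among the compounds shown here, this position therefore responds strongly to a change of just one heavy atom, something the earlier compounds could not show, as their steps all concern the aryl group on the amide-type nitrogen and are smaller: a number 15.8 percentage points lower from compound 1 to compound 2 (beyond the scatter) and a number 23.1 percentage points lower from compound 1 to compound 3 (beyond the scatter). The information available gives no measured property that bears on this fall.

The compounds shown leave open whether the loss is specific to fluoro or would also follow from a different group on this carbon, such as chloro, methyl or methoxy. They also leave open whether fluoro on the remaining carbons of this ring would lower the read-out as far, and whether the same fluoro would have a comparable effect alongside the 3-hydroxyphenyl or the 2-fluorophenyl on the amide-type nitrogen.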